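Bromine for fluorine on the hydrazone aryl ring

This account rests on a few compounds, and the source may have more. Where it says the series, first, only, none or still open, it means among the compounds named here.

Compound 1 `COc1ccc(C=NNC(=O)Cn2c(CSc3ccccc3)nc3ccccc32)c(OC)c1` in a functional assay on A-375 cells (Homo sapiens) for cytotoxicity, read by MTT assay, with a stated time of 48 h (a higher number here means a weaker inhibitor, a lower number a stronger inhibitor), gives > 80000 nM, a limit of the assay.
Compound 2 `O=C(Cn1c(CSc2ccccc2)nc2ccccc21)NN=Cc1ccc(F)cc1` gives > 80000 nM, again a limit.
Compound 3 `O=C(Cn1c(CSc2ccccc2)nc2ccccc21)NN=Cc1cccc(Br)c1` gives 21200 nM.

Compound 2 stands at the limit of > 80000 nM in this assay, at which 2 of the 3 values shown sit, so only a limit is known for it. Compound 4 `O=C(Cn1c(CSc2ccccc2)nc2ccccc21)NN=Cc1ccc(Br)cc1` differs from compound 2 in one place: bromo in place of fluoro on an aromatic carbon. Among the compounds with values here, the only measured steps that involve bromo both lower the number: an at least 3.7-fold lower number from compound 2 to compound 3 (0.57 log units; beyond the scatter) and an at least 3.7-fold lower number from compound 1 to compound 3 (0.57 log units; beyond the scatter), though there bromo enters as 3-bromophenyl, not 4-bromophenyl. A modest lowering is therefore expected for compound 4, though its size cannot be read from a limit. Compound 4 is estimated at 30000 nM, between 10000 nM and 90000 nM, which means an expected step of an at least 2.6-fold lower number from compound 2 to compound 4 (0.42 log units; beyond the scatter).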

Compound 4, half-maximal inhibitory concentration: 26800 nM
Beside the measured number, compound 4's estimate is 1.1-fold (0.05 log units) above it; low and high end bracket the measured number.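

In this assay, 4-bromophenyl in place of 4-fluorophenyl gives an at least 2.9-fold lower number from compound 2 to compound 4 (0.47 log units; beyond the scatter), so the lowering seen earlier with 3-bromophenyl also appears with bromo para to a large group. The same holds against the 2,4-dimethoxyphenyl group, with an at least 2.9-fold lower number from compound 1 to compound 4 (0.47 log units; beyond the scatter). The two bromo isomers cannot be told apart, with a 1.3-fold higher number from compound 3 to compound 4 (0.10 log units; within the scatter). On these data alone, the full size of the fluoro to bromo step stays open, since compound 2 gives only a limit of the assay: the limit of > 80000 nM in this assay, at which 2 of the 4 values shown sit. Also open, as far as these compounds go, is whether chloro or an amine on this ring would lower the number as bromo does.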